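The source may report more compounds than this note shows. Statements on the series, on what has been measured and on what is new or still open speak of the compounds shown alone.

Among the measured compounds shown here, in a functional assay on HeLa cells (Homo sapiens) for antiproliferative activity, read by cell counting, with a stated time of 2 days (on this read-out lower numbers stand for stronger inhibition and higher numbers for weaker inhibition), compound 1 `COc1cc(C(=O)c2sc(Nc3ccccc3)nc2N)cc(OC)c1OC` gives 14 nM, the lower of the two numbers measured so far. Compound 2 `COc1ccc(C(=O)c2sc(Nc3ccccc3)nc2N)cc1OC` gives 6000 nM in this assay. That gap, a 430-fold higher number from compound 1 to compound 2 (2.63 log units; beyond the scatter), is large and beyond the scatter, and it comes from hydrogen in place of methoxy on an aromatic carbon, away from the anilino group.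

Compound 3 `COc1cc(C(=O)c2sc(Nc3ccc(F)cc3)nc2N)cc(OC)c1OC` has not yet been measured. It differs from compound 1 as follows: fluoro in place of hydrogen on an aromatic carbon. In other words, the anilino group of compound 1 becomes (4-fluorophenyl)amino.

For the measured compounds named here, no measured step touches this group, so the large step to compound 2 gives no direct guide to either size or direction here. It shows only how far the number can move at another place. Only a modest rise in this assay is therefore expected, far smaller than that step, and with little confidence in its direction. The estimated change is a 2.1-fold higher number from compound 1 to compound 3 (0.33 log units; beyond the scatter). For compound 3 the expected value is 30 nM, within an estimated range of 8 nM to 120 nM.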

Compound 3, half-maximal inhibitory concentration: 440 nM
Estimate against measurement, compound 3: 15-fold (1.17 log units) below, outside the stated range (above it).
By their numbers in this assay, from the lowest: compound 1; then compound 3; then compound 2.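

In this assay the anilino group proves to be a place where a very small change matters: fluoro in place of hydrogen on an aromatic carbon, para to a large group, brings one fluorine atom and gives a 31-fold higher number from compound 1 to compound 3 (1.50 log units; beyond the scatter), a large step. The earlier pair had shown a large step only at the methoxy group, a 430-fold higher number from compound 1 to compound 2 (2.63 log units; beyond the scatter), and so said nothing about the far side of the molecule; the number is now seen to depend on both places, though the step at the methoxy group remains the larger of the two. Nothing measured here accounts for the rise on adding fluoro, so the result stands as an observation without an explanation.

The compounds shown leave open whether this rise belongs to fluoro itself or would follow any group on the same carbon, such as chloro, methyl or an amine. They also leave open whether the hydrogen at this carbon is the best group available there, and whether fluoro elsewhere on that six-membered ring would carry the same cost.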